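A Further Chloro on the Benzyl Ring

The compounds below may be only part of what the source reports. "The series", "measured", "known", "first", "only" and "open" are said of these compounds alone.

Measured compounds:
Compound 1 `O=[N+]([O-])c1cc(C(F)(F)F)cc([N+](=O)[O-])c1Oc1ccc(Cl)cc1/C=N\OCc1ccccc1`: 1790 nM
Compound 2 `O=[N+]([O-])c1cc(C(F)(F)F)cc([N+](=O)[O-])c1Oc1ccc(Cl)cc1/C=N\OCc1ccccc1Cl`: 1510 nM
Compound 3 `O=[N+]([O-])c1cc(C(F)(F)F)cc([N+](=O)[O-])c1Oc1c(Cl)cc(Cl)cc1/C=N/OCc1ccccc1Cl`: 1120 nM

The three measured compounds were tested in a functional assay on HepG2 cells (Homo sapiens) for antiproliferative activity, read by MTT assay, with a stated time of 48 h; a higher number here means a weaker inhibitor, a lower number a stronger inhibitor. Compound 2 differs from compound 1 by chloro in place of hydrogen on an aromatic carbon, and this change gave a 1.2-fold lower number from compound 1 to compound 2 (0.07 log units; within the scatter). Compound 3 carries a different core from compound 1; the difference between the two cores is not broken down here. In this assay compound 3 gives 1120 nM, and its gaps to compound 2 and to compound 1 lie within the usual scatter, so no order among the three can be claimed.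

Compound 4 `O=[N+]([O-])c1cc(C(F)(F)F)cc([N+](=O)[O-])c1Oc1c(Cl)cc(Cl)cc1/C=N/OCc1ccc(Cl)cc1Cl` has not yet been measured. It differs from compound 3 by chloro in place of hydrogen on an aromatic carbon. Among the measured compounds shown here, this is the same kind of change as the one from compound 1 to compound 2, but not the same: there the entering chloro sat ortho to a large group, whereas here it sits meta to a chloro group and para to a large group. The expected step of a 1.1-fold lower number from compound 3 to compound 4 (0.05 log units; within the scatter) is small because a 1.2-fold lower number from compound 1 to compound 2 (0.07 log units; within the scatter) was itself within the scatter. Compound 4 is therefore expected to give about 1000 nM, with a likely range from 500 nM to 2000 nM.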

Compound 4, half-maximal inhibitory concentration: 940 nM
For compound 4 the middle estimate is 1.1-fold (0.03 log units) above the measured one; the range from low to high includes it.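

In this assay, going from 2-chlorobenzyl to 2,4-dichlorobenzyl gives a 1.2-fold lower number from compound 3 to compound 4 (0.08 log units; within the scatter). Set beside the earlier chloro step on the other core, the two steps agree: the same change on two cores in this assay, a 1.2-fold lower number (0.07 log units; within the scatter) from compound 1 to compound 2 and a 1.2-fold lower number (0.08 log units; within the scatter) from compound 3 to compound 4, 1.0-fold (0.00 log units) apart, within the scatter of two such steps. This shows only that, on both cores, putting a chloro in place of hydrogen on the benzyl ring gave a step that cannot be told apart from repeat-measurement scatter; it does not show a real gain that carries from one core to the other, and the two chloro groups enter at different places on that ring, so these are not strictly the same change.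

Going by these compounds, it remains open whether a different group on the benzyl ring, such as a methoxy group, a nitrile or an amine, would give a step beyond the scatter. Also open, on these data alone, is what would happen if the benzyl group itself gave way to a longer alkyl chain or a carboxylic acid.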